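Cytotoxicity notes on an acylthiourea series

This account rests on a few compounds, and the source may have more. Where it says the series, first, only, none or still open, it means among the compounds named here.

Measured so far:
compound 1, `O=C(NC(=S)N1CCc2ccc(OCc3ccccc3)cc21)c1ccccc1` — 43800 nM
compound 2, `O=C(NC(=S)N1CCc2c(OCCCCCOc3ccc(Cl)cc3)cccc21)c1ccc(C(F)(F)F)cc1` — 32700 nM

In an ADME assay on Huh-7 cells (Homo sapiens) for cytotoxicity (on this read-out lower numbers stand for higher toxicity in this test and higher numbers for lower toxicity in this test), compound 1 gives 43800 nM. In this assay compound 2 gives 32700 nM. The two numbers lie within the scatter of each other, so compound 2 cannot be set apart from compound 1 on this read-out; both sit in the same weakly toxic region.

The next compound is compound 3, `O=C(NC(=S)N1CCc2c(OCCCCCOc3ccc(Cl)cc3)cccc21)c1ccco1`. It differs from compound 2 in one place: furan-2-yl in place of 4-(trifluoromethyl)phenyl on a carbonyl carbon. Among the measured compounds shown here, no comparable step between two measured compounds exists, so there is nothing in the data to anchor the size of this change. As compound 1 and compound 2 give values within the scatter of each other despite their differing acyl groups, the step of a 1.2-fold higher number from compound 2 to compound 3 (0.09 log units; within the scatter) is expected to stay within the scatter, with no clear direction. Compound 3 is therefore expected to give about 40000 nM in this assay, in a range from 15000 nM to 100000 nM.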

Compound 3, half-maximal cytotoxic concentration: 4620 nM
The estimate for compound 3 lay 8.7-fold (0.94 log units) above the measured number; measured number outside the range, below it.
By their numbers in this assay, from the lowest: compound 3; then compounds 2 and 1 (each within the scatter of the next).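

The acyl group on the carbonyl carbon is not a silent position in this assay: with the rest of compound 2 held fixed, furan-2-yl in place of 4-(trifluoromethyl)phenyl gives a 7.1-fold lower number from compound 2 to compound 3 (0.85 log units; beyond the scatter), toward higher toxicity in this test. Compounds 1 and 2 could not show this, as they differ in more than one place and their values lie within the scatter of each other. Nothing available explains this step.

As far as these compounds go, it remains open whether the step belongs to the furan ring itself, to the loss of the trifluoromethyl group, or to the change of ring size; plain phenyl or thiophen-2-yl on the same carbonyl carbon would separate these readings. From the compounds shown here alone, whether the same exchange carries over to the core and ether group of compound 1 also remains open.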